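A few compounds are considered here, and "the series" means these few. Any claim that something is new, unique, unknown or untested is made for them only; others in the source may bear on it.

Of the compounds shown here, two have so far been tested in a functional assay on the whole organism with Rattus norvegicus as the target, read by paw edema, with a stated time of 3 h, at a dose of 100 mg/kg by the oral route; a higher number here means more inhibition at the dose given (going by the name of the read-out), a lower number less inhibition. Compound 1 `CCc1ccc(-c2nc3cc(Cl)ccc3[nH]2)nc1` gives -2%. Where compound 1 has a chlorine, compound 2 `CCc1ccc(-c2nc3cc(N)ccc3[nH]2)nc1` carries an amino group, and compound 2 gives 25%. Going by the values given here, of these two numbers compound 2 stands highest, and its only neighbour is compound 1, separated by the step of a number 27 percentage points higher from compound 1 to compound 2 (beyond the scatter).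

Compound 3 `CCc1ccc(-c2nc3cc(NC(C)=O)ccc3[nH]2)nc1` is the next candidate. It keeps the whole of compound 2 and changes only one place: acetyl in place of hydrogen on a nitrogen on an aromatic ring. The aromatic ring and its other substituent are untouched.

Among the compounds with values here, no measured step speaks directly to this change. Within the data shown here, the single step available, from chloro to amino, shows that the group at this position can move the read-out by a modest amount, but it says nothing about capping the amino nitrogen with an acetyl group. In this assay the step is therefore expected to be small, without a clear direction, and a change of a number 5 percentage points lower from compound 2 to compound 3 (within the scatter) is estimated. Compound 3 is expected to give 20%, within a range from 0% to 40%.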

Compound 3, a percentage reported as inhibition, in the whole organism at one dose (the size of the read-out at that dose, not a potency): 5%
Estimate against measurement, compound 3: 15 percentage points above; low and high end bracket the measured number.
By their numbers in this assay, from the lowest: compounds 1 and 3 (each within the scatter of the next); then compound 2.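

In this assay, the gain seen with the amino group does not survive once its nitrogen carries an acetyl group, giving a number 20 percentage points lower from compound 2 to compound 3 (beyond the scatter). The position therefore responds not only to which atom is attached to the aromatic carbon but also to what that nitrogen carries, since amino and acetamido both attach through nitrogen yet are separated by a step beyond the scatter. Acetamido and chloro cannot be told apart here, with a number 7 percentage points higher from compound 1 to compound 3 (within the scatter), so among these three compounds only the free amino group of compound 2 stands out, and no measurement is available to explain why.

From the compounds shown here alone, it remains open whether any group on this nitrogen would lower the number or whether the drop belongs to acetyl in particular, a question that a methyl group on the nitrogen or a methanesulfonyl group in place of the acetyl would help to settle. Going by these compounds, it is also open whether a different group on the aromatic carbon, such as a hydroxyl group or a carboxylic acid, would match or pass the number of compound 2.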